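Sec-butyl to isobutyl in an antiproliferative pair

This account rests on a few compounds, and the source may have more. Where it says the series, first, only, none or still open, it means among the compounds named here.

compound 1 `CC(C)(C)Nc1nc2ccccc2nc1Oc1ccc(C(=O)NCC(=O)O)cc1`: > 50000 nM (a limit)
compound 2 `CC[C@@H](C)[C@H](NC(=O)c1ccc(Oc2nc3ccccc3nc2NC(C)(C)C)cc1)C(=O)O`: 18300 nM

In a functional assay on K562 cells (Homo sapiens) for antiproliferative activity, read by MTT assay, with a stated time of 48 h (on this read-out higher numbers stand for weaker inhibition and lower numbers for stronger inhibition), compound 1 is recorded only as a limit, > 50000 nM. Within the data shown here, compound 2, at 18300 nM, holds the only actual number so far. Among the measured compounds shown here, the one measured step is an at least 2.7-fold lower number from compound 1 to compound 2 (0.43 log units; beyond the scatter). Compound 3 `CC(C)C[C@H](NC(=O)c1ccc(Oc2nc3ccccc3nc2NC(C)(C)C)cc1)C(=O)O` has the same atoms as compound 2, joined differently: isobutyl in place of sec-butyl on a saturated chain carbon bound to an amide-type nitrogen and a carbonyl carbon. The measured step replaced hydrogen, so it bears only loosely on this exchange of one four-carbon chain for another. The best anchor is compound 2 at 18300 nM, and no clear direction can be drawn from it. The expected change is no more than the scatter, with an estimated 1.0-fold lower number from compound 2 to compound 3 (0.01 log units; within the scatter). For compound 3 the estimated value in this assay is 18000 nM, with an expected range of 9000 nM to 40000 nM.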

Compound 3, half-maximal inhibitory concentration: 42300 nM
Beside the measured number, compound 3's estimate is 2.4-fold (0.37 log units) below it; measured number outside the range, above it.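

In this assay the place on a saturated chain carbon bound to an amide-type nitrogen and a carbonyl carbon responds not only to the presence of a chain but also to how it is joined. Sec-butyl and isobutyl have the same heavy-atom count, yet isobutyl in place of sec-butyl gives a 2.3-fold higher number from compound 2 to compound 3 (0.36 log units; beyond the scatter) as a modest difference. Isobutyl in place of hydrogen gives an at least 1.1-fold lower number from compound 1 to compound 3 (0.07 log units; that floor lies within the scatter) and so only a floor for that step. Compound 1 is recorded only as a limit: the limit of > 50000 nM in this assay, at which 1 of the 3 values shown sits.

As far as these compounds go, how a benzyl group or a longer straight chain would read at this place remains open. So does the effect of a methyl ester in place of the carboxylic acid.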